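Taking one methoxy away from compound 2

This account rests on a few compounds, and the source may have more. Where it says the series, first, only, none or still open, it means among the compounds named here.

Measured in a functional assay on HeLa cells (Homo sapiens) for antiproliferative activity, read by sulforhodamine B assay, with a stated time of 48 h; a lower number here means a stronger inhibitor, a higher number a weaker inhibitor

Compound 1 `COc1cc(OC)c2sc(-c3ccc(N/C=C\C(=O)c4ccc(OC)c([N+](=O)[O-])c4)c(C)c3)nc2c1` gives 9390 nM

Compound 2 `COc1ccc(C(=O)/C=C\Nc2ccc(-c3nc4cc(OC)c(OC)c(OC)c4s3)cc2C)cc1F` gives 1200 nM

Of these two numbers, compound 2 holds the lower one, which makes it the stronger inhibitor of the pair, and the gap to compound 1 lies beyond the usual scatter. The two compounds differ in more than one place, so that gap cannot be pinned on any single group.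

Compound 3 `COc1cc(OC)c2sc(-c3ccc(N/C=C\C(=O)c4ccc(OC)c(F)c4)c(C)c3)nc2c1` departs from compound 2 in one place, with hydrogen in place of methoxy on an aromatic carbon and the rest of the molecule unchanged. Among the measured compounds shown here, no measured pair shows this change alone, so any forecast is loose. For the measured compounds named here, the core of compound 3 does match the core of compound 1, and that match is the only guide here, with compound 1 at the weaker number (9390 nM). A modest move toward weaker inhibition in this assay therefore seems likely, only a little beyond the scatter. The expected move is a 2.5-fold higher number from compound 2 to compound 3 (0.40 log units; beyond the scatter) on this estimate. For compound 3 the estimated value is 3000 nM (expected range 800 nM to 10000 nM).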

Compound 3, half-maximal inhibitory concentration: 14700 nM
Compound 3: middle estimate off by 4.9-fold (0.69 log units), on the low side, outside the stated range (above it).
By their numbers in this assay, from the lowest: compound 2; then compounds 1 and 3 (each within the scatter of the next).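

Taking away the methoxy that sits ortho to two methoxy groups brings a 12-fold higher number from compound 2 to compound 3 (1.09 log units; beyond the scatter) in this assay, a large step and the first evidence from a single change that this position matters for antiproliferative activity in these cells. The other single change now available, fluoro in place of nitro on an aromatic carbon, gives a 1.6-fold higher number from compound 1 to compound 3 (0.19 log units; within the scatter) and stays within the scatter, so on the core lacking this methoxy, these two groups cannot be told apart in this assay. The numbers record how much activity is lost with the methoxy gone, but nothing here explains that loss.

Going by these compounds, what remains open is whether the methoxy itself is needed, or whether another group on the same aromatic carbon, such as an ethoxy, a hydroxyl or a chlorine atom, would hold the activity of compound 2. The compounds shown also leave open whether restoring this methoxy would bring a similar gain when nitro replaces fluoro on the other ring.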